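Swapping a saturated ring for an aromatic one in a solubility series

The compounds below may be only part of what the source reports. "The series", "measured", "known", "first", "only" and "open" are said of these compounds alone.

Of the compounds shown here, three sharing one core have been measured in a physicochemical assay for solubility, with a stated time of 18 h, at pH 7.4; a higher number here means a more soluble compound, a lower number a less soluble compound. Compound 1 `COc1cccc(CNCCCNc2ccnc3cc(Oc4ccc(Cl)cc4)ccc23)c1O` gives 14500 nM and compound 2 `COc1ccc(Oc2ccc3c(NCCCNCc4cccc(OC)c4O)ccnc3c2)cc1` gives 14500 nM, a pair separated by no change at the digits printed from compound 1 to compound 2 (within the scatter). Compound 3 `COc1cccc(CNCCCNc2ccnc3cc(CC4CCCCC4)ccc23)c1O` gives 4200 nM, the lowest of the three numbers, reached through a 3.5-fold lower number from compound 1 to compound 3 (0.54 log units; beyond the scatter) and through a 3.5-fold lower number from compound 2 to compound 3 (0.54 log units; beyond the scatter). Compound 4 `COc1cccc(CNCCCNc2ccnc3cc(CCc4ccccc4)ccc23)c1O` has not yet been measured in this assay. It differs from compound 3 in one place: benzyl in place of cyclohexyl on a saturated chain carbon bound to an aromatic carbon. Among the measured compounds shown here, no measured step swaps a saturated ring for an aromatic ring at a chain carbon, so the two steps above, both of which exchanged an aryl ether for a cyclohexylmethyl group, bear on this change only loosely; they show that a change at this position can move solubility modestly. The expected step is therefore small, most likely toward a higher number, and written as a 1.5-fold higher number from compound 3 to compound 4 (0.19 log units; within the scatter). Compound 4 is thus estimated at 6500 nM, with a range from 2500 nM to 15000 nM.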

Compound 4, solubility: 4200 nM
For compound 4 the middle estimate is 1.5-fold (0.19 log units) above the measured one, and the stated range covers the measured number.
By their numbers in this assay, from the lowest: compounds 3 and 4 (each within the scatter of the next); then compounds 1 and 2 (each within the scatter of the next).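

Within this assay, replacing the saturated ring of cyclohexyl with the aromatic ring of benzyl on this chain gives no change at the digits printed from compound 3 to compound 4 (within the scatter) and so does not separate this pair of compounds. Phenethyl in place of 4-methoxyphenoxy gives a 3.5-fold lower number from compound 2 to compound 4 (0.54 log units; beyond the scatter) and phenethyl in place of 4-chlorophenoxy gives a 3.5-fold lower number from compound 1 to compound 4 (0.54 log units; beyond the scatter) in steps that match those already seen with cyclohexylmethyl, so the two carbon-linked ring groups stand apart from the two aryl ether groups by the same amount. No measurement shown here explains these numbers.

On these data alone, whether a phenethyl group carrying an amine or a carboxylic acid would match compound 4 remains open. So does whether a longer chain in place of phenethyl would leave the solubility reading unchanged.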